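The compounds below may be only part of what the source reports. "The series", "measured", "known", "first", "only" and "open" are said of these compounds alone.

Two compounds of the series carry a halogen on the fused ring system of the shared core. Compound 1 `O=C(Nc1ccc(Cl)cc1)C(=O)N1CCC(c2ccnc3ccc(F)cc23)CC1` gives 15 nM in an assay on SK-OV-3 cells for inhibition of Indoleamine 2,3-dioxygenase 1 (Homo sapiens) (on this read-out lower numbers stand for stronger inhibition and higher numbers for weaker inhibition), and compound 2 `O=C(Nc1ccc(Cl)cc1)C(=O)N1CCC(c2ccnc3ccc(Cl)cc23)CC1` gives 19 nM. The step of a 1.3-fold higher number from compound 1 to compound 2 (0.10 log units; within the scatter) shows that exchanging one halogen for the other leaves the read-out unchanged. Compound 2 stands with the higher of the two numbers, yet its distance from compound 1 is within the scatter, so no order can be read between them.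

Compound 3 `N#Cc1ccc2nccc(C3CCN(C(=O)C(=O)Nc4ccc(Cl)cc4)CC3)c2c1` differs from compound 2 in one place: cyano in place of chloro on an aromatic carbon. Among the measured compounds shown here, no measured compound carries a cyano group, so the halogen exchange is the only step that bears on this position, and it was small. From the compounds shown here alone, whether a cyano group is tolerated alike is unknown. The estimated step is a 1.3-fold higher number from compound 2 to compound 3 (0.12 log units; within the scatter), no more than the scatter. For compound 3 the expected value in this assay is 25 nM, within 8 nM to 80 nM.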

Compound 3, half-maximal inhibitory concentration: 118 nM
Compound 3: the middle estimate sits 4.7-fold (0.67 log units) below what was measured, and the stated range ends below it.
By their numbers in this assay, from the lowest: compounds 1 and 2 (each within the scatter of the next); then compound 3.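

In this assay cyano in place of either halogen gives a 6.2-fold higher number from compound 2 to compound 3 (0.79 log units; beyond the scatter) and a 7.9-fold higher number from compound 1 to compound 3 (0.90 log units; beyond the scatter) on the same aromatic carbon. This position therefore does respond to its substituent, which the exchange of one halogen for the other, within the scatter, gave no sign of, and the cyano compound separates from both halogen compounds. Nothing among the data shown accounts for this step, so its cause remains unassigned.

Whether the higher number is particular to the cyano group or extends to other non-halogen substituents stays open, as an amine, a methoxy group or a carboxylic acid on this carbon lies outside the compounds shown. The unsubstituted core is also absent, so the halogen and cyano compounds have no common reference point.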